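Two-Ring Group Gives Way to a Chlorinated Single Ring

The compounds below may be only part of what the source reports. "The series", "measured", "known", "first", "only" and "open" are said of these compounds alone.

Compound 1 `COc1ccc(C2=NN(C(C)=O)C(c3ccc(OCc4cn(Cc5ccc([N+](=O)[O-])cc5)nn4)c(OC)c3)C2)cc1`: 14%
Compound 2 `COc1cc(C2CC(c3cccc4ccccc34)=NN2C(C)=O)ccc1OCc1cn(Cc2ccc([N+](=O)[O-])cc2)nn1`: 79%

In a functional assay on THP-1 cells (Homo sapiens) for inhibition, read by sulforhodamine B assay, tested at 100 uM (on this read-out higher numbers stand for more inhibition of growth at the one concentration tested and lower numbers for less inhibition of growth), compound 2 gives 79%, the higher of the two numbers; compound 1 gives 14%. Compound 3 `COc1cc(C2CC(c3ccc(Cl)cc3)=NN2C(C)=O)ccc1OCc1cn(Cc2ccc([N+](=O)[O-])cc2)nn1` differs from compound 2 in one place: 4-chlorophenyl in place of naphthalen-1-yl on a carbon with a double bond to nitrogen. Among the compounds with values here, the only measured step that bears on this is a number 65 percentage points higher from compound 1 to compound 2 (beyond the scatter), where a single ring was replaced by two fused rings. Compound 3 returns to a single ring, so compound 3 is expected to give back much of that gain, because of a number 65 percentage points higher from compound 1 to compound 2 (beyond the scatter), as a number 44 percentage points lower from compound 2 to compound 3 (beyond the scatter). Compound 3 is therefore estimated at 35%, in a range from 10% to 65%.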

Compound 3, percent growth inhibition at one concentration: 37%
Estimate against measurement, compound 3: 2 percentage points below, within the range that was stated.
By their numbers in this assay, from the lowest: compound 1; then compound 3; then compound 2.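

In this assay the new group sits in the middle, with a number 42 percentage points lower from compound 2 to compound 3 (beyond the scatter) and also a number 23 percentage points higher from compound 1 to compound 3 (beyond the scatter). Two fused rings are therefore not the only way to raise growth inhibition at this carbon: with a single ring kept, chloro in place of methoxy also gives a gain, though a smaller one than naphthalen-1-yl gives. Nothing measured here explains why these groups rank this way. On these data alone, how an amine or a carboxylic acid in place of the chloro group would fare remains open.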